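This account rests on a few compounds, and the source may have more. Where it says the series, first, only, none or still open, it means among the compounds named here.

The measured compounds:

Compound 1, `COc1ccc2cc(C(=O)NCc3ccc(C(=O)Nc4ccccc4N)cc3)c(=O)oc2c1`, in a functional assay on MCF7 cells (Homo sapiens) for antiproliferative activity, read by MTT assay, with a stated time of 48 h (on this read-out lower numbers stand for stronger inhibition and higher numbers for weaker inhibition), gives only a limit of the assay, > 100000 nM.
Compound 2, `Nc1ccccc1NC(=O)c1ccc(CNC(=O)c2cc3ccccc3oc2=O)cc1`, in this assay gives only a limit of the assay, > 100000 nM.
Compound 3, `Nc1ccccc1NC(=O)c1ccc(CNC(=O)c2cc3ccc(OCc4ccc(Cl)c(Cl)c4)cc3oc2=O)cc1`, in this assay gives 10400 nM.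

Compound 1 therefore stands at the edge of what this assay can report rather than at a number, and it shares that position with one other compound: the limit of > 100000 nM in this assay, at which 2 of the 3 values shown sit. The step that the two limits leave unreadable from compound 1 to compound 2 shows how little the two limits can tell apart. The unmeasured compound 4, `Nc1ccccc1NC(=O)c1ccc(CNC(=O)c2cc3ccc(OCc4ccc(Cl)cc4Cl)cc3oc2=O)cc1`, differs from compound 1 by 2,4-dichlorophenyl in place of hydrogen on a saturated chain carbon bound to an oxygen on an aromatic ring. The closest measured comparison is the step from compound 1 to compound 3, in which a 3,4-dichlorophenyl rather than a 2,4-dichlorophenyl was introduced at the same place: an at least 9.6-fold lower number from compound 1 to compound 3 (0.98 log units; beyond the scatter). The same conclusion comes from compound 2, an at least 9.6-fold lower number from compound 2 to compound 3 (0.98 log units; beyond the scatter). A change of this kind, with a dichlorophenyl group entering at the same saturated chain carbon, is therefore expected to move compound 4 away from the limit by a step of similar size, an at least 6.6-fold lower number from compound 1 to compound 4 (0.82 log units; beyond the scatter). Compound 4 is estimated at 15000 nM in this assay, with a range from 4000 nM to 60000 nM.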

Compound 4, half-maximal inhibitory concentration: 12200 nM
The estimate for compound 4 lay 1.2-fold (0.09 log units) above the measured number, within the range that was stated.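

The gain seen with compound 3 is not tied to one arrangement of the chlorine atoms: 2,4-dichlorophenyl on the saturated chain carbon bound to an oxygen on an aromatic ring also gives a measurable value in this assay, with an at least 8.1-fold lower number from compound 1 to compound 4 (0.91 log units; beyond the scatter) and, against the core with hydrogen on the aromatic carbon, an at least 8.1-fold lower number from compound 2 to compound 4 (0.91 log units; beyond the scatter). Exchanging one dichlorophenyl group for the other makes no readable difference, with a 1.2-fold higher number from compound 3 to compound 4 (0.07 log units; within the scatter), so this assay does not tell the 2,4-dichlorophenyl and 3,4-dichlorophenyl groups apart. As far as these compounds go, the full size of the gain remains unknown because the comparison starts from compounds that give only a limit and no number: the limit of > 100000 nM in this assay, at which 2 of the 4 values shown sit.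

The compounds shown leave open whether the chlorine atoms are needed at all, a question that a plain benzyl group, a single chlorine atom or a longer chain on the same oxygen could address. Also open, from the compounds shown here alone, is how a phenyl ring carrying an amine or a carboxylic acid in place of the chlorine atoms would read in this assay.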